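The source may hold more compounds than are shown below. What is called first, only, known or untested is meant among the compounds shown, and "the series" means these compounds.

Measured so far:
Compound 1, `COC1=C(C)C(=O)/C(=C(O)/C=C/c2ccccc2C)C(=O)C1(C)C`, gives 4 ug/mL in a functional assay on HCT-8 cells (Homo sapiens) for cytotoxicity; on this read-out lower numbers stand for an effect already at smaller amounts and higher numbers for an effect only at larger amounts of compound.
Compound 2, `COC1=C(C)C(=O)/C(=C(O)/C=C/c2c(C)cccc2C)C(=O)C1(C)C`, gives 7.8 ug/mL.
Compound 3, `CCC1=C(OC)C(CC)(CC)C(=O)C(C(=O)/C=C/c2ccccc2)=C1O`, gives 3.7 ug/mL.

Compound 4, `CCC1=C(OC)C(CC)(CC)C(=O)C(C(=O)/C=C/c2ccc(C)cc2)=C1O`, has not yet been measured. Compound 3 and compound 4 share a core that is not the core of compound 1 and compound 2; the difference between the two cores is not broken down here. The change from compound 1 to compound 2 is methyl in place of hydrogen on an aromatic carbon, and in this assay it gave a 2.0-fold higher number from compound 1 to compound 2 (0.29 log units; within the scatter). Compound 4 carries the same kind of change relative to compound 3, (methyl in place of hydrogen on an aromatic carbon), but the surroundings are not the same: in compound 2 the entering methyl sits ortho to a large group and meta to a methyl group, whereas in compound 4 it sits para to a large group. For the measured compounds named here, for compound 4 the expected step is a 1.5-fold higher number from compound 3 to compound 4 (0.17 log units; within the scatter), resting on the single measured example a 2.0-fold higher number from compound 1 to compound 2 (0.29 log units; within the scatter), a step within the scatter. Compound 4 is therefore expected to give about 5.5 ug/mL, with a likely range from 2.5 ug/mL to 12 ug/mL.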

Compound 4, concentration for half-maximal effect: 9.4 ug/mL
For compound 4 the middle estimate is 1.7-fold (0.23 log units) below the measured one; measured number inside the range.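

In this assay, methyl in place of hydrogen on the aromatic ring gives a 2.5-fold higher number from compound 3 to compound 4 (0.40 log units; beyond the scatter), so on this core the change costs a modest amount of effect. For the compounds shown here, the earlier example on the other core points the same way, and the two steps agree in size as closely as repeated measurements allow: the same change on two cores in this assay, a 2.0-fold higher number (0.29 log units; within the scatter) from compound 1 to compound 2 and a 2.5-fold higher number (0.40 log units; beyond the scatter) from compound 3 to compound 4, 1.3-fold (0.11 log units) apart, within the scatter of two such steps This suggests that the change carries over between these two cores, but it rests on only two pairs, one of which is within the scatter on its own, and the methyl does not stand in the same place on the ring in both pairs, so it shows neither a general rule nor why the number rises.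

The compounds shown leave open whether ethyl, a longer chain, an amine or a carboxylic acid in place of that methyl would shift the number in the same way. Going by these compounds alone, they also leave open how the two cores compare on their own, as no pair here differs in the core alone.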